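The source may report more compounds than this note shows. Statements on the series, on what has been measured and on what is new or still open speak of the compounds shown alone.

The account opens with compound 1, `CCN(C)Cc1c(OC)cc(OC)c(C(=O)/C=C/c2ccccc2Cl)c1O`, which in a functional assay on HL-60 cells (Homo sapiens) for antiproliferative activity, with a stated time of 72 h (on this read-out higher numbers stand for weaker inhibition and lower numbers for stronger inhibition), gives 200 nM. Within the data shown here, the only other measured compound is compound 2, `COc1cc(O)c2c(=O)cc(-c3ccccc3Cl)oc2c1CN1CCCCC1`, and in this assay compound 2 gives 48100 nM. Among the measured compounds shown here, of the two numbers, the one for compound 1 is the lower, and the distance between these two values lies well beyond the usual scatter of this kind of measurement; the two structures share no single point of difference, so nothing more is drawn from that pair than the two values themselves.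

Compound 3, `CCN(CC)Cc1c(OC)cc(OC)c(C(=O)/C=C/c2ccccc2Cl)c1O`, has not yet been measured in this assay. Its departure from compound 1 is counted as methyl in place of hydrogen on a saturated chain carbon bound to an amine nitrogen — that is, the (ethyl(methyl)amino)methyl group becomes a (diethylamino)methyl group, and the rest of the shared core is untouched. For the measured compounds named here, no measured pair shows a change of this kind, so there is no guide to its size. The expectation is that compound 3 lands close to compound 1, with a step of a 1.3-fold higher number from compound 1 to compound 3 (0.10 log units; within the scatter) that stays within the scatter rather than pointing clearly either way. Compound 3 is therefore estimated at 250 nM, with a range from 80 nM to 800 nM.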

Compound 3, half-maximal inhibitory concentration: 30900 nM
The estimate for compound 3 lay 120-fold (2.09 log units) below the measured number; the measured number lies above the stated range.
By their numbers in this assay, from the lowest: compound 1; then compounds 3 and 2 (each within the scatter of the next).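

In this assay, among these compounds, the exchange of the (ethyl(methyl)amino)methyl group for a (diethylamino)methyl group gives the first reading of a change in a single place, and it is a 150-fold higher number from compound 1 to compound 3 (2.19 log units; beyond the scatter) on the shared core. This shows that the place on a saturated chain carbon bound to an amine nitrogen is far from indifferent in this series: a single methyl in place of hydrogen, one added carbon with the rest of the structure untouched, is enough to move the number by this much. No measurement at hand explains why so small a change is tied to so large a step.

The compounds shown leave open whether the step grows gradually with the size of the amine substituent or appears abruptly, and a (dimethylamino)methyl group, a propyl chain on the nitrogen or a morpholine ring at this place would each help to tell these apart. As far as these compounds go, it also remains open whether the same methyl change would give a step of similar size on a different core.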